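The source may report more compounds than this note shows. Statements on the series, on what has been measured and on what is new or still open speak of the compounds shown alone.

Three compounds have been measured in a functional assay on HCT-15 cells (Homo sapiens) for inhibition, read by sulforhodamine B assay, with a stated time of 48 h; a higher number here means a weaker inhibitor of growth, a lower number a stronger inhibitor of growth:

Compound 1 `COc1cc(-c2cc(/C=C/C(=O)c3ccc(N)cc3)[nH]n2)cc(OC)c1OC` gives 1370 nM.
Compound 2 `COc1ccc(-c2cc(/C=C/C(=O)c3ccc(N)cc3)[nH]n2)cc1OC` gives 1700 nM.
Compound 3 `COc1cc(C(=O)/C=C/c2cc(-c3cc(OC)c(OC)c(OC)c3)n[nH]2)cc(OC)c1OC` gives 1500 nM.

Compound 1 and compound 2 share one core and differ in a single place: hydrogen in place of methoxy on an aromatic carbon. That change made a step of a 1.2-fold higher number from compound 1 to compound 2 (0.09 log units; within the scatter). Compound 3 is built on a different core; how its core differs from that of compound 1 is not broken down here. Its value and that of compound 1 lie within the usual scatter of each other, and the same holds for compound 3 and compound 2.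

Compound 4 `COc1ccc(-c2cc(/C=C/C(=O)c3cc(OC)c(OC)c(OC)c3)[nH]n2)cc1OC` has not yet been measured. It arises from compound 3 by the same change: hydrogen in place of methoxy on an aromatic carbon. The surroundings of the place are the same as in the change from compound 1 to compound 2, so this is the same change, not merely the same kind of change. Because the earlier change gave a 1.2-fold higher number from compound 1 to compound 2 (0.09 log units; within the scatter), the step in this assay is expected to be small here as well, about a 1.2-fold higher number from compound 3 to compound 4 (0.08 log units; within the scatter). For compound 4 the estimate is 1800 nM, with a range from 900 nM to 3600 nM.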

Compound 4, concentration for 50% growth inhibition: 1190 nM
The estimate for compound 4 lay 1.5-fold (0.18 log units) above the measured number; low and high end bracket the measured number.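

In this assay, putting hydrogen in place of methoxy on the second core gave a 1.3-fold lower number from compound 3 to compound 4 (0.10 log units; within the scatter). Set beside the earlier step, this shows that the change carried over from one core to the other with no difference that can be told apart from ordinary assay noise: the same change on two cores in this assay, a 1.2-fold higher number (0.09 log units; within the scatter) from compound 1 to compound 2 and a 1.3-fold lower number (0.10 log units; within the scatter) from compound 3 to compound 4, 1.6-fold (0.19 log units) apart, within the scatter of two such steps It does not show that the methoxy group has a real effect on either core, or that it has none beyond what this assay can detect, and two cores are too few to support a rule for the whole series.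

The compounds shown hold only methoxy or hydrogen at this place, so it remains open whether a hydroxyl group, a carboxylic acid or a longer chain such as ethoxy would move the number beyond the scatter. As far as these compounds go, all of these numbers also come from this assay, so it remains open whether the same change would behave alike in other cell lines.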